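Dimethylamino for Methoxy on the Chain of Compound 2

This account rests on a few compounds, and the source may have more. Where it says the series, first, only, none or still open, it means among the compounds named here.

Measured compounds:
compound 1, `CCSC[C@@](O)([C@@H](Nc1cccc2nc(C)ccc12)c1ccc(F)cc1OC)C(F)(F)F`, 78%
compound 2, `COC[C@@](O)([C@@H](Nc1cccc2nc(C)ccc12)c1ccc(OC)c(F)c1Cl)C(F)(F)F`, 97%

Two compounds carry a measured value in a functional assay on THP-1 cells (Homo sapiens); a higher number here means a larger maximal response, a lower number a smaller maximal response. Compound 1 is `CCSC[C@@](O)([C@@H](Nc1cccc2nc(C)ccc12)c1ccc(F)cc1OC)C(F)(F)F` and in this assay compound 1 gives 78%. Compound 2 is `COC[C@@](O)([C@@H](Nc1cccc2nc(C)ccc12)c1ccc(OC)c(F)c1Cl)C(F)(F)F` and in this assay compound 2 gives 97%, the higher of the two numbers; the gap between compound 1 and compound 2 lies beyond the usual scatter. The two compounds differ in more than one place, so only their two values can be compared.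

Compound 3, `COc1ccc([C@H](Nc2cccc3nc(C)ccc23)[C@](O)(CN(C)C)C(F)(F)F)c(Cl)c1F`, has not yet been measured in this assay. It departs from compound 2 in a single change: dimethylamino in place of methoxy on a saturated chain carbon, two bonds along the chain from an oxygen on a saturated carbon. Within the data shown here, no single-point step between measured compounds is available, so there is no precedent for what this exchange on the saturated chain does to the maximal response.

Given only the value of compound 2 at 97% and the absence of a comparable step, compound 3 is expected to give 88%, within the range 65% to 105%. The step from compound 2 to compound 3 is thus estimated at a number 9 percentage points lower from compound 2 to compound 3 (within the scatter), a small downward move that may not exceed the scatter.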

Compound 3, largest response reached (Emax), in percent of the reference or control that the assay uses in the THP-1 assay: 77%
Beside the measured number, compound 3's estimate is 11 percentage points above it, within the range that was stated.
By their numbers in the THP-1 assay, from the lowest: compounds 3 and 1 (each within the scatter of the next); then compound 2.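

Among these compounds, this pair gives the first comparison that differs in one place, and so the first direct reading of what happens on this saturated chain carbon, two bonds along the chain from an oxygen on a saturated carbon. In the THP-1 assay, putting dimethylamino in place of methoxy there gives a number 20 percentage points lower from compound 2 to compound 3 (beyond the scatter), so the maximal response responds to this exchange even though the hydrogen-bond acceptor count of the group stays the same. In a physicochemical assay for lipophilicity (on this read-out lower numbers stand for lower lipophilicity and higher numbers for higher lipophilicity), compound 2 gives 3.8 and compound 3 gives 5.3, so the same exchange that lowers the maximal response also raises lipophilicity: the measured partition coefficient of compound 2, 3.8, and of compound 3, 5.3, a number 1.50 log units higher (beyond the scatter)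

A single pair cannot tell whether the lower maximal response follows from the higher lipophilicity, from the amine nitrogen itself, or from the extra heavy atom of the entering group. From the compounds shown here alone, how a morpholine, a pyrrolidine or a free hydroxyl on the same chain carbon would place the maximal response and the partition coefficient remains open, as does whether the step carries over to other substitution on the shared core.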